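Ester to Acid on a Shared Core

The source may report more compounds than this note shows. Statements on the series, on what has been measured and on what is new or still open speak of the compounds shown alone.

Compound 1 `CC#CCn1c(N2CCC[C@@H](N)C2)cc(=O)n(Cc2cccc(C(=O)O)c2Br)c1=O` — in an assay on isolated protein for inhibition of Dipeptidyl peptidase 9 (Homo sapiens), read by fluorescence, with stated times of 15 min and 20 min (a higher number here means a weaker inhibitor, a lower number a stronger inhibitor), compound 1 gives "not determined" (no result reported).
Compound 2 `CC#CCn1c(N2CCC[C@@H](N)C2)cc(=O)n(Cc2ccc(Cl)c(C(=O)O)c2)c1=O` — in this assay compound 2 gives > 100 nM, a limit of the assay.
Compound 3 `CC#CCn1c(N2CCC[C@@H](N)C2)cc(=O)n(Cc2ccc(Br)c(C(=O)OC)c2)c1=O` — in this assay compound 3 gives > 100 nM, also a limit.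

Compound 3 therefore stands at the limit of > 100 nM in this assay, at which 2 of the 3 values shown sit, and no single number is shown for any compound. Compound 4 `CC#CCn1c(N2CCC[C@@H](N)C2)cc(=O)n(Cc2ccc(Br)c(C(=O)O)c2)c1=O` differs from compound 3 by hydrogen in place of methyl on an oxygen next to a carbonyl group, so methoxycarbonyl becomes carboxy. No step between measured compounds is shown, so no size can be read from the data. Compound 2 also carries a carboxy, and its value in this assay, > 100 nM, is a limit. Compound 4 is therefore expected to stay near that limit, with the step that the limit leaves unreadable from compound 3 to compound 4 expected to be small, giving an estimate of 300 nM (range 80 nM to 2000 nM).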

Compound 4, half-maximal inhibitory concentration: > 100 nM
Compound 4: no number, only a limit; the forecaster's own chance of this, stated with the estimate: 70%; the middle value is on the limit's open side.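

Among the compounds shown here, no step to compound 4 can be read from compound 3 or compound 2, since all three values are limits: the limit of > 100 nM in this assay, at which 3 of the 4 values shown sit.

In this assay, as far as these compounds go, it stays open how strongly each compound inhibits, and whether swapping methoxycarbonyl for carboxy or chloro for bromo changes that.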